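Benzyl in place of sec-butyl on an aromatic nitrogen

The source may hold more compounds than are shown below. What is called first, only, known or untested is meant among the compounds shown, and "the series" means these compounds.

Compound 1 `CCC(C)n1cnc2c(NCc3ccc(C(=O)Nc4ccccc4N)cc3)nc(Cl)nc21` stands second highest of the three numbers in a functional assay on HepG2 cells (Homo sapiens) for antiproliferative activity, read by CCK-8 assay, with a stated time of 72 h, tested at 8 uM (on this read-out higher numbers stand for a stronger effect at the one concentration tested and lower numbers for a weaker effect), where compound 1 gives 65%. Compound 2 `Nc1ccccc1NC(=O)c1ccc(Cn2cnc3c(Nc4ccccc4)nc(Cl)nc32)cc1` gives 74.8% in this assay, and compound 3 `CCCCn1cnc2c(Nc3ccccc3)nc(NCOCc3ccc(/C=C/C(=O)Nc4ccccc4N)cc3)nc21` gives 59.3% there; both numbers lie within the scatter of compound 1, so the three cannot be put in order. Compound 4 `Nc1ccccc1NC(=O)c1ccc(CNc2nc(Cl)nc3c2ncn3Cc2ccccc2)cc1` is not yet measured. It differs from compound 1 in one place: benzyl in place of sec-butyl on an aromatic nitrogen. For the measured compounds named here, no step between measured compounds matches this change. As all numbers seen so far sit within the scatter of one another, no step beyond the scatter is expected in either direction. The expected step of a number 1 percentage points higher from compound 1 to compound 4 (within the scatter) is therefore small. For compound 4 the estimate is 66%, with a range from 52% to 80%.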

Compound 4, a percentage reported as inhibition, at one concentration (the size of the read-out at that concentration, not a potency): 5.32%
Estimate against measurement, compound 4: 60.7 percentage points above; the measured number lies below the stated range.
By their numbers in this assay, from the lowest: compound 4; then compounds 3, 1 and 2 (each within the scatter of the next, the first and the last beyond it).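

On the aromatic nitrogen of the shared core, this assay is highly sensitive to the substituent: benzyl in place of sec-butyl gives a number 59.7 percentage points lower from compound 1 to compound 4 (beyond the scatter). The earlier compounds shown here offered no step at this position, and this single change now shows that it can decide most of the read-out. No measurement available here bears on the reason for this step. Open, as far as these compounds go, is whether the step follows the aromatic ring or simply the larger group: cyclohexylmethyl on the same nitrogen would separate the two, and methyl would show how smaller groups behave.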